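The compounds below may be only part of what the source reports. "The series", "measured", "known", "first", "only" and "open" are said of these compounds alone.

Measured compounds:
compound 1 `CCCCCCCCCCCCNC(=O)[C@@H](NC(=O)c1cccs1)[C@@H](C)O` — 29200 nM
compound 2 `CCCCCCCCCCCCCCNC(=O)[C@@H](NC(=O)c1cccs1)[C@@H](C)O` — 78400 nM
compound 3 `CCCCCCCCCCCCCCCCCCNC(=O)[C@@H](NC(=O)c1cccs1)[C@@H](C)O` — 200000 nM

In a functional assay on SW-620 cells (Homo sapiens) for cytotoxicity, read by MTT assay, with a stated time of 48 h (a lower number here means a stronger inhibitor, a higher number a weaker inhibitor), compound 3 gives 200000 nM, the highest number of the three. Its nearest neighbour is compound 2, which gives 78400 nM; compound 1 gives 29200 nM. All three measured steps concern the saturated chain: a 2.7-fold higher number from compound 1 to compound 2 (0.43 log units; beyond the scatter), a 2.6-fold higher number from compound 2 to compound 3 (0.41 log units; beyond the scatter) and a 6.8-fold higher number from compound 1 to compound 3 (0.84 log units; beyond the scatter). Each lengthening of the chain has brought a higher number, beyond the scatter, with no exception among these three compounds.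

Compound 4 `CCCCCCCCCCCCCCCCCCNC(=O)[C@@H](NS(=O)(=O)c1ccc(C)cc1)[C@@H](C)O` keeps the chain of compound 3 and changes the other end: (4-methylphenyl)sulfonyl in place of (thiophen-2-yl)carbonyl on an amine nitrogen. Going by the values given here, no measured step touches this position; the chain steps say nothing about what a sulfonyl in place of a carbonyl does here, and the data hold no pair that does. Among the compounds with values here, the only anchor is compound 3 itself, which already stands at the top of the range seen so far in this assay. Within the data shown here, with no step to carry over, the expectation is no change beyond the scatter, and the estimated step is no change at the digits printed from compound 3 to compound 4 (within the scatter). Compound 4 is therefore expected to give about 200000 nM in this assay, within a range of 60000 nM to 600000 nM, with a real chance that only a limit is reported.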

Compound 4, half-maximal inhibitory concentration: 32500 nM
Compound 4: middle estimate off by 6.2-fold (0.79 log units), on the high side, outside the stated range (below it).
By their numbers in this assay, from the lowest: compounds 1 and 4 (each within the scatter of the next); then compound 2; then compound 3.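

The position on the amine nitrogen, untouched by the chain steps, is shown here to move the result in this assay: with the chain of compound 3 kept, (4-methylphenyl)sulfonyl in place of (thiophen-2-yl)carbonyl gives a 6.2-fold lower number from compound 3 to compound 4 (0.79 log units; beyond the scatter). This step runs opposite in direction to the chain steps, such as a 2.6-fold higher number from compound 2 to compound 3 (0.41 log units; beyond the scatter), so the high number of compound 3 is not set by its chain alone. No measurement at hand accounts for the step.

On these data alone, the sulfonyl group appears on only one chain, so it remains open whether the step would have the same size and direction on the shorter chains of compound 1 and compound 2, or on a longer chain. The step also changes the linking group and the ring together, so a (thiophen-2-yl)sulfonyl or a (4-methylphenyl)carbonyl group on the same amine nitrogen would be needed to tell whether the sulfonyl or the 4-methylphenyl ring goes with the lower number.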